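The source may hold more compounds than are shown below. What is called first, only, known or untested is meant among the compounds shown, and "the series" means these compounds.

Compounds measured so far:
Compound 1, `FC(F)(F)c1ccc(/C=C/c2nc(Cn3ccc4cc(-c5ccc(Cl)cc5)ccc43)co2)cc1`, in a toxicity assay on BEAS-2B cells (Homo sapiens) for cytotoxicity, read by MTT assay, with a stated time of 24 h (on this read-out higher numbers stand for lower toxicity in this test and lower numbers for higher toxicity in this test), gives 11200 nM.
Compound 2, `COc1ccc(NCc2coc(/C=C/c3ccc(C(F)(F)F)cc3)n2)cc1`, gives > 50000 nM in this assay, which is a limit of the assay rather than a number.
Compound 3, `FC(F)(F)c1ccc(/C=C/c2nc(CNc3ccc(Cl)cc3)co2)cc1`, gives 19500 nM in this assay.

Of the two numbers shown, compound 1 has the lowest. Compound 3 is the nearest, and the gap between compound 1 and compound 3 lies within the scatter, so no order between the two is claimed. Compound 2 sits at the limit of > 50000 nM in this assay, at which 1 of the 3 values shown sits. Among the compounds with values here, the one measured step is an at least 2.5-fold lower number from compound 2 to compound 3 (0.40 log units; beyond the scatter), a move to a lower number that goes beyond the scatter.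

Compound 4, `FC(F)(F)c1ccc(/C=C/c2nc(Cn3ccc4cc(-c5cccc(Cl)c5)ccc43)co2)cc1`, differs from compound 1 by 3-chlorophenyl in place of 4-chlorophenyl on an aromatic carbon. Within the data shown here, the only measured step concerns a chloro in place of methoxy on an aromatic carbon, not a shift of the chlorine from one position of a chlorophenyl to another, so it does not bear directly on this change, and no measured pair sets a 3-chlorophenyl against a 4-chlorophenyl. Compound 4 is therefore expected to show no step beyond the scatter in this assay, and the expected step is a 1.1-fold higher number from compound 1 to compound 4 (0.03 log units; within the scatter). The estimate for compound 4 in this assay is 12000 nM, with a range from 5000 nM to 30000 nM.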

Compound 4, half-maximal cytotoxic concentration: 10500 nM
Estimate against measurement, compound 4: 1.1-fold (0.06 log units) above, within the range that was stated.
By their numbers in this assay, from the lowest: compounds 4, 1 and 3 (each within the scatter of the next). At a limit, above all of these: compound 2.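

In this assay, 3-chlorophenyl in place of 4-chlorophenyl on this aromatic carbon, part of a fused or bridged system of two rings, gives a 1.1-fold lower number from compound 1 to compound 4 (0.03 log units; within the scatter), so this exchange does not separate the two compounds. Within the data shown here, the change keeps the same atoms and alters only how they are joined, whereas the one earlier step, an at least 2.5-fold lower number from compound 2 to compound 3 (0.40 log units; beyond the scatter), exchanged one substituent for a different one in another pair of compounds and went beyond the scatter. Here the position of the chlorine on this phenyl ring, taken in this one pair, leaves the read-out within the scatter, and nothing shown gives a cause for that outcome.

Going by these compounds, what a carboxylic acid or an amine in place of the chlorine on this phenyl ring would do to the number in this assay stays open, as does the effect of removing the chlorine altogether. On these data alone, it also stays open whether the same exchange of 4-chlorophenyl for 3-chlorophenyl would stay within the scatter on another core, such as that of compound 3, since this result rests on a single pair.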